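From 2,5-difluorophenyl to 2,6-difluorophenyl: working notes

A few compounds are considered here, and "the series" means these few. Any claim that something is new, unique, unknown or untested is made for them only; others in the source may bear on it.

Among the compounds with values here, in a functional assay on Jurkat cells (Homo sapiens) (a higher number here means a weaker inhibitor, a lower number a stronger inhibitor), compound 1 `CC(C)[C@H](NC(=O)COc1cccc2ccccc12)C(=O)N[C@@H](CC(=O)O)C(=O)COc1ccc(-c2ccccc2)cc1` gives 87900 nM as the only true number so far. Compound 2 `CC(C)[C@H](NC(=O)COc1cccc2ccccc12)C(=O)N[C@@H](CC(=O)O)C(=O)COc1ccccc1[N+](=O)[O-]` reads > 100000 nM and that is a limit. Compound 3 `CC(C)[C@H](NC(=O)COc1cccc2ccccc12)C(=O)N[C@@H](CC(=O)O)C(=O)COc1cc(F)ccc1F` reads > 100000 nM and that too is a limit. The series is thus marked by the limit of > 100000 nM in this assay, at which 2 of the 3 values shown sit, and compound 3 stands there, with no number of its own.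

Compound 4 `CC(C)[C@H](NC(=O)COc1cccc2ccccc12)C(=O)N[C@@H](CC(=O)O)C(=O)COc1c(F)cccc1F` is an isomer of compound 3: 2,6-difluorophenyl in place of 2,5-difluorophenyl on an oxygen on a saturated carbon with 2,6-difluorophenyl in place of 2,5-difluorophenyl on an oxygen on a saturated carbon.

The measured steps give little to go on. The step of an at least 1.1-fold higher number from compound 1 to compound 3 (0.05 log units; that floor lies within the scatter) and the step of an at least 1.1-fold higher number from compound 1 to compound 2 (0.05 log units; that floor lies within the scatter) are floors only, and the closest comparison, a step that the two limits leave unreadable from compound 2 to compound 3 has no readable size. Given the step of an at least 1.1-fold higher number from compound 1 to compound 3 (0.05 log units; that floor lies within the scatter) no change beyond the scatter is expected, and a further limit is the likeliest report. The estimated step is an at least 1.1-fold lower number from compound 3 to compound 4 (0.04 log units; that floor lies within the scatter) with no direction expected. The expected value for compound 4 is 90000 nM with an estimated range of 30000 nM to 200000 nM in this assay for now.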

Compound 4, half-maximal inhibitory concentration: 2040 nM
Compound 4: middle estimate off by 44-fold (1.64 log units), on the high side; measured number outside the range, below it.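

The change from 2,5-difluorophenyl to 2,6-difluorophenyl on an oxygen on a saturated carbon gives an at least 49-fold lower number from compound 3 to compound 4 (1.69 log units; beyond the scatter) with the same atoms joined differently, so in these compounds the arrangement of the two fluorines on the ring counts, not only their presence. Within the data shown here, the 2,6-difluorophenyl group also stands apart from 2-nitrophenyl, with an at least 49-fold lower number from compound 2 to compound 4 (1.69 log units; beyond the scatter) as a floor set by a limit, and from 4-phenylphenyl, with a 43-fold lower number from compound 1 to compound 4 (1.63 log units; beyond the scatter) as the one step here that has a true number at both ends. Compound 4 thus stands well clear of the limit that compound 2 and compound 3 share: the limit of > 100000 nM in this assay, at which 2 of the 4 values shown sit.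

As far as these compounds go, what a 2,6-dichlorophenyl or a 2-fluorophenyl group would give on the same oxygen stays open, so the step cannot yet be tied to the two fluorines as such. From the compounds shown here alone, the step from compound 2 to compound 3 cannot be read, and the order of those two stays open as well.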